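Swapping Fluoro for Cyclopropyl in Compound 4

A few compounds are considered here, and "the series" means these few. Any claim that something is new, unique, unknown or untested is made for them only; others in the source may bear on it.

In an ADME assay (liver) for metabolic stability, with Liver microsome (Canis lupus familiaris) as the target, read by LC-MS, using microsomes, with a stated time of 30 min, tested at 4 uM (a lower number here means that less of the compound is left, a higher number that more of the compound is left), compound 1 `Cc1nc(N2CCN(C)CC2)c2nc(-c3cccc(Cl)c3)n(C3CCOCC3)c2n1` gives 45% and compound 2 `COc1cccc(-c2nc3c(N4CCN(C)CC4)nc(C)nc3n2C2CCOCC2)c1` gives 46% with a step of a number 1 percentage points higher from compound 1 to compound 2 (within the scatter) between them. Compound 3 `Cc1nc(N2CCN(C)CC2)c2nc(-c3ccccc3F)n(C3CCOCC3)c2n1` has the lowest number of the three at 21% and is the starting point for compound 4 `Cc1nc(N2CCN(C)CC2)c2nc(-c3ccccc3C3CC3)n(C3CCOCC3)c2n1`. The change cyclopropyl in place of fluoro on an aromatic carbon puts cyclopropyl in place of fluoro on an aromatic carbon. Going by the values given here, only the modest steps of a number 24 percentage points lower from compound 1 to compound 3 (beyond the scatter) and a number 25 percentage points lower from compound 2 to compound 3 (beyond the scatter) bear on it, and loosely: they exchange the whole substituted phenyl, and no measured compound carries cyclopropyl. No shift beyond the scatter is therefore expected, with an estimated a number 3 percentage points higher from compound 3 to compound 4 (within the scatter) in this assay overall. The estimate for compound 4 is 24% with 8% to 45% as its expected range.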

Compound 4, percent of the compound remaining: 69%
Estimate against measurement, compound 4: 45 percentage points below; measured number outside the range, above it.
By their numbers in this assay, from the lowest: compound 3; then compounds 1 and 2 (each within the scatter of the next); then compound 4.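

In this assay, going by these compounds alone, cyclopropyl on this aromatic carbon, ortho to a large group, gives a number 48 percentage points higher from compound 3 to compound 4 (beyond the scatter), so the group held here matters far more than the earlier compounds could show. The 2-cyclopropylphenyl compound also stands apart from both other aryl variants, with a number 23 percentage points higher from compound 2 to compound 4 (beyond the scatter) and a number 24 percentage points higher from compound 1 to compound 4 (beyond the scatter). Nothing shown accounts for this rise. The compounds leave open whether an open chain such as isopropyl or ethyl at this place would give a similar number or whether the three-membered ring is required.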